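This account rests on a few compounds, and the source may have more. Where it says the series, first, only, none or still open, it means among the compounds named here.

Measured in a functional assay on brain (Rattus norvegicus, strain Wistar) for inhibition; a lower number here means a stronger inhibitor, a higher number a weaker inhibitor:
- Compound 1 `Cc1[nH]c(=O)n(C)c1-c1ccc(-c2ccccc2)cc1`: 6300 nM
- Compound 2 `Cc1[nH]c(=O)n(C2CCCCC2)c1-c1ccc(OC(C)C)cc1`: 13000 nM
- Compound 3 `Cc1[nH]c(=O)n(C2CCCCC2)c1-c1ccc(C2CCCCC2)cc1`: 28900 nM

Compound 3 has the highest number of the three, which makes it the weakest inhibitor measured so far. Compound 4 `Cc1[nH]c(=O)n(C2CCCCC2)c1-c1ccc(-c2ccccc2)cc1` is compound 3 with phenyl in place of cyclohexyl on an aromatic carbon, para to a large group: phenyl in place of cyclohexyl on an aromatic carbon. Going by the values given here, no measured step covers this exchange directly. The closest is a change at the same place, cyclohexyl in place of isopropoxy, which gave a 2.2-fold higher number from compound 2 to compound 3 (0.35 log units; beyond the scatter), a modest step. Compound 1, at 6300 nM, already carries phenyl at that place, though it differs from compound 4 in a second place as well. On this evidence, a modest step towards a lower number is expected in this assay, with little certainty about its size. The estimated change is a 2.1-fold lower number from compound 3 to compound 4 (0.31 log units; beyond the scatter). The expected value for compound 4 is 14000 nM, with an estimated range of 5000 nM to 35000 nM.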

Compound 4, half-maximal inhibitory concentration: 10900 nM
The estimate for compound 4 lay 1.3-fold (0.11 log units) above the measured number, and the stated range covers the measured number.
By their numbers in this assay, from the lowest: compounds 1, 4 and 2 (each within the scatter of the next, the first and the last beyond it); then compound 3.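

In this assay, phenyl in place of cyclohexyl on the aromatic carbon gave a 2.7-fold lower number from compound 3 to compound 4 (0.42 log units; beyond the scatter), so two groups of equal heavy-atom count, one aromatic and one non-aromatic, are told apart at this place. Phenyl in place of isopropoxy gave a 1.2-fold lower number from compound 2 to compound 4 (0.08 log units; within the scatter), and cyclohexyl in place of methyl on the aromatic nitrogen gave a 1.7-fold higher number from compound 1 to compound 4 (0.24 log units; within the scatter), so neither of these exchanges can be told from the usual scatter, and among the groups at the aromatic carbon only cyclohexyl stands apart. Nothing available explains the difference between phenyl and cyclohexyl here.

On these data alone, what an amine or a carboxylic acid would do at this aromatic carbon remains open. So does whether phenyl in place of cyclohexyl gives a similar step with methyl on the aromatic nitrogen.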